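The source may report more compounds than this note shows. Statements on the series, on what has been measured and on what is new or still open speak of the compounds shown alone.

Of the compounds shown here, three have been measured in a functional assay for agonist activity at 5-hydroxytryptamine receptor 4 (Homo sapiens), read by cAMP accumulation; on this read-out higher numbers stand for larger maximal responses and lower numbers for smaller maximal responses. Compound 1 `CC(=O)N(C)CC(O)CN1CCC(CNC(=O)c2cccc3[nH]c(C(C)C)nc23)CC1` gives 64%, compound 2 `COC(=O)N1CCN(CCN2CCC(CNC(=O)c3cccc4[nH]c(C(C)C)nc34)CC2)CC1` gives 72%, and compound 3 `CS(=O)(=O)N1CCN(CC(O)CN2CCC(CNC(=O)c3cccc4[nH]c(C5CC5)nc34)CC2)CC1` gives 64%. Compound 3 therefore stands level with compound 1 at the digits shown, and both lie within the scatter of compound 2. Among the compounds with values here, the only step between two compounds that differ in one place, a number 8 percentage points higher from compound 1 to compound 2 (within the scatter), also stays within the scatter, so the measured numbers form a narrow band.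

Compound 4 `CC(C)(C)c1nc2c(C(=O)NCC3CCN(CC(O)CN4CCN(S(C)(=O)=O)CC4)CC3)cccc2[nH]1` differs from compound 3 in one place: tert-butyl in place of cyclopropyl on an aromatic carbon. Within the data shown here, no measured step touches this position. The step from compound 1 to compound 2 alters the chain on the ring amine instead, and compound 3 differs from compound 1 in two places at once, so their equal values cannot be traced to a single change. Among the measured compounds shown here, because compound 3 gives 64% and the one measured step of a number 8 percentage points higher from compound 1 to compound 2 (within the scatter) stays within the scatter, the expectation for compound 4 is a step of no change at the digits printed from compound 3 to compound 4 (within the scatter), that is, no change beyond the scatter. Compound 4 is thus estimated at 64%, with a likely range from 48% to 80%.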

Compound 4, intrinsic activity: the largest response reached, in percent of the reference agonist's: 94%
Compound 4: middle estimate off by 30 percentage points, on the low side; the measured number lies above the stated range.
By their numbers in this assay, from the lowest: compounds 1, 3 and 2 (each within the scatter of the next); then compound 4.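

In this assay, tert-butyl in place of cyclopropyl on the aromatic carbon between two ring nitrogen atoms gives a number 30 percentage points higher from compound 3 to compound 4 (beyond the scatter). Within the data shown here, this shows that the maximal response can respond to a small change at this position, with only one heavy atom added and no hydrogen-bond donor or acceptor gained, whereas the one earlier single-place step, a number 8 percentage points higher from compound 1 to compound 2 (within the scatter), changed the chain on the ring amine and stayed within the scatter. No measurement shown accounts for the rise.

Still open, going by these compounds, is whether the rise follows the loss of the ring or the added carbon, and a cyclobutyl group at this position could help to separate the two. Also open, on these data alone, is whether tert-butyl would give a similar rise with the other side chains on the ring amine, such as those of compound 1 and compound 2.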